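The source may report more compounds than this note shows. Statements on the series, on what has been measured and on what is new or still open speak of the compounds shown alone.

Measured compounds in a functional assay on MCF7 cells (Homo sapiens) for cytotoxicity, read by MTT assay, with a stated time of 24 h; a higher number here means a weaker inhibitor, a lower number a stronger inhibitor:
- compound 1 `Cc1ccc(-c2nnc(N3CCN(C(=O)CN4CCN(c5ccccc5)CC4)CC3)nc2-c2ccc(C)cc2)cc1` gives 914000 nM
- compound 2 `COc1cccc(N2CCN(CC(=O)N3CCN(c4nnc(-c5ccc(C)cc5)c(-c5ccc(C)cc5)n4)CC3)CC2)c1` gives 867000 nM
- compound 3 `COc1ccc(N2CCN(CC(=O)N3CCN(c4nnc(-c5ccc(C)cc5)c(-c5ccc(C)cc5)n4)CC3)CC2)cc1` gives 53000 nM

Compound 3 holds the lowest number of the three in this assay; both other compounds sit well apart from it, beyond the scatter. Within this set only compound 3 carries its methoxy where it does.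

Compound 4 `Cc1ccc(-c2nnc(N3CCN(C(=O)CN4CCN(c5ccc([N+](=O)[O-])cc5)CC4)CC3)nc2-c2ccc(C)cc2)cc1` differs from compound 3 by nitro in place of methoxy on an aromatic carbon, on an aromatic carbon of a six-membered aromatic ring of carbon only, para to a large group.

Within the data shown here, two measured steps touch the same position: a 17-fold lower number from compound 1 to compound 3 (1.24 log units; beyond the scatter) and a 16-fold lower number from compound 2 to compound 3 (1.21 log units; beyond the scatter), both large drops in number tied to the methoxy at that place. Neither step, nor a 1.1-fold lower number from compound 1 to compound 2 (0.02 log units; within the scatter), involves a nitro, so nothing measured here tells how a nitro behaves at that position. The only firm point is that removing the methoxy from that carbon returns the number to the range of compound 1.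

Compound 4 is therefore expected to land between compound 1 and compound 3, most likely nearer the higher numbers, as an estimate of 250000 nM with a range of 40000 nM to 1000000 nM, meaning an expected step of a 4.7-fold higher number from compound 3 to compound 4 (0.67 log units; beyond the scatter).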

Compound 4, half-maximal inhibitory concentration: 845000 nM
Compound 4: the middle estimate sits 3.4-fold (0.53 log units) below what was measured, within the range that was stated.
By their numbers in this assay, from the lowest: compound 3; then compounds 4, 2 and 1 (each within the scatter of the next).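

In this assay, the low number at this carbon does not carry over from 4-methoxyphenyl to 4-nitrophenyl (a 16-fold higher number from compound 3 to compound 4 (1.20 log units; beyond the scatter)), so it does not hold for every group placed there. Nitro at this carbon cannot be told apart from hydrogen (a 1.1-fold lower number from compound 1 to compound 4 (0.03 log units; within the scatter)) or from the 3-methoxyphenyl arrangement (a 1.0-fold lower number from compound 2 to compound 4 (0.01 log units; within the scatter)), which leaves 4-methoxyphenyl as the only one of the four to stand apart. No measurement at hand gives a reason for the gap between methoxy and nitro at this position.

Still open, going by these compounds, is whether an amine, a hydroxyl or an ethoxy at this carbon would stay with methoxy or fall in with nitro and hydrogen. The compounds shown also leave open whether a chloro or a carboxylic acid there would separate from that group.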